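A few compounds are considered here, and "the series" means these few. Any claim that something is new, unique, unknown or untested is made for them only; others in the source may bear on it.

Measured so far:
- Compound 2, `CC(C)C(NC(=O)NO)C(=O)NC1CCCC1`: in a functional assay on HEp-2 cells (Homo sapiens) for inhibition (a lower number here means a stronger inhibitor, a higher number a weaker inhibitor), compound 2 gives 33400 nM.
- Compound 1, `CCC(C)C(NC(=O)NO)C(=O)NC1CCCCC1`: for compound 1 the entry > 100000 nM in this assay is a limit, not a number.

Going by the values given here, compound 2 thus stands alone as the only numerical value in this assay; the other entry is a limit (the limit of > 100000 nM in this assay, at which 1 of the 2 values shown sits). Among the compounds with values here, no pair of measured compounds differs in a single place, so no measured step is available to lean on.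

Compound 3, `CCC(C)C(NC(=O)NO)C(=O)NC1CCCC1`, is the next candidate. It differs from compound 2 by methyl in place of hydrogen on a saturated chain carbon, three bonds along the chain from an amide-type nitrogen and a carbonyl carbon. Compound 1 carries the same sec-butyl chain as compound 3 but differs from it elsewhere as well, and compound 1 sits at the assay limit while compound 2 returns a number; that is all the two values show.

For the step from compound 2 to compound 3 in this assay a loss somewhat beyond the usual scatter is expected, toward weaker inhibition, with the estimated step of a 1.9-fold higher number from compound 2 to compound 3 (0.29 log units; within the scatter). Compound 3 is estimated at 65000 nM, with a range from 20000 nM to 160000 nM, and a real chance that this assay returns only a limit for it.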

Compound 3, half-maximal inhibitory concentration: > 100000 nM
Compound 3: only a limit was reported; the forecaster's own chance of this, stated with the estimate: 40%; middle value at least 1.5-fold (0.18 log units) from the limit.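

In this assay, going by these compounds alone, methyl in place of hydrogen on a saturated chain carbon, three bonds along the chain from an amide-type nitrogen and a carbonyl carbon, gives an at least 2.9-fold higher number from compound 2 to compound 3 (0.47 log units; beyond the scatter), so this one added carbon takes the only numerical value to the limit. Isopropyl to sec-butyl is therefore the first change in one place with a readable direction, and that direction is toward weaker inhibition on the cyclopentyl amide. The step between cyclohexyl and cyclopentyl on the sec-butyl chain cannot be read, as compound 1 and compound 3 both give only limits, and the series now rests largely on such entries: the limit of > 100000 nM in this assay, at which 2 of the 3 values shown sit.

As far as these compounds go, the true size of the loss stays open, since the entry for compound 3 is a limit and not a number, and so does the effect of cyclohexyl in place of cyclopentyl on the isopropyl chain. Also open, from the compounds shown here alone, is how a shorter chain such as ethyl, a longer chain, an amine or a carboxylic acid on this saturated chain carbon would read in this assay.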